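Exchanging 4-methoxyphenyl for 2-acetylphenyl on an aromatic nitrogen

The compounds below may be only part of what the source reports. "The series", "measured", "known", "first", "only" and "open" are said of these compounds alone.

In a functional assay on MCF7 cells (Homo sapiens) for cytotoxicity, read by MTT assay, with a stated time of 48 h (a lower number here means a stronger inhibitor, a higher number a weaker inhibitor), compound 1 `C=C1CCC[C@]2(C)CCC(C=O)=CC[C@@]12C` gives 319000 nM and compound 2 `C#CC1=CC[C@@]2(C)C(=C)CCC[C@]2(C)CC1` gives 575000 nM while compound 3 `C=C1CCC[C@]2(C)CCC(c3cn(-c4ccc(OC)cc4)nn3)=CC[C@@]12C` gives 118000 nM as the lowest of the three numbers. Compound 4 `C=C1CCC[C@]2(C)CCC(c3cn(-c4ccccc4C(C)=O)nn3)=CC[C@@]12C` differs from compound 3 by 2-acetylphenyl in place of 4-methoxyphenyl on an aromatic nitrogen and in nothing else. For the measured compounds named here, the only measured step is a 1.8-fold higher number from compound 1 to compound 2 (0.26 log units; within the scatter) and it lies within the scatter. That step puts ethynyl in place of formyl on a double-bonded ring carbon and leaves the aromatic nitrogen out of play. Going by the values given here, no measured pair changes the group on that nitrogen, so no step beyond the scatter is expected in this assay in either direction. The step is estimated as a 1.1-fold higher number from compound 3 to compound 4 (0.04 log units; within the scatter) for now. The estimate for compound 4 is 130000 nM with an expected range from 60000 nM to 280000 nM at this stage.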

Compound 4, half-maximal inhibitory concentration: 29900 nM
The estimate for compound 4 lay 4.3-fold (0.64 log units) above the measured number, outside the stated range (below it).
By their numbers in this assay, from the lowest: compound 4; then compound 3; then compounds 1 and 2 (each within the scatter of the next).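

In this assay, the group on the aromatic nitrogen of the five-membered ring can move the number beyond the scatter: 2-acetylphenyl in place of 4-methoxyphenyl gives a 3.9-fold lower number from compound 3 to compound 4 (0.60 log units; beyond the scatter). For the compounds shown here, the earlier compounds held no change at this nitrogen, so this is the first sign that the position responds. No evidence is available that accounts for this step. The compounds shown leave open whether the step goes with the entering acetyl or the departing methoxy, and how an amine or a carboxylic acid on that phenyl ring would read.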